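The source may report more compounds than this note shows. Statements on the series, on what has been measured and on what is new or still open speak of the compounds shown alone.

Compound 1 `O=C(c1nn(-c2ccccc2)c2c1CC(NCc1ccccc1)CC2)N1CCCCC1`: 631 nM
Compound 2 `O=C(c1nn(Cc2ccccc2)c2c1CC(NCc1ccc(F)cc1)CC2)N1CCCCC1`: 251 nM

In an assay on HEK293 cells for displacement of a labelled ligand from Sigma non-opioid intracellular receptor 1 (Homo sapiens), read by scintillation counting, with a stated time of 120 min (on this read-out higher numbers stand for weaker inhibition and lower numbers for stronger inhibition), compound 2 gives 251 nM, the lower of the two numbers, while compound 1 gives 631 nM, a gap beyond the usual scatter. Compound 3 `O=C(c1nn(-c2ccccc2)c2c1CC(NCc1ccc(F)cc1)CC2)N1CCCCC1` awaits measurement. It differs from compound 2 in one place: phenyl in place of benzyl on an aromatic nitrogen. Within the data shown here, no pair of measured compounds isolates this change, as compound 1 and compound 2 differ in two places at once. A modest rise is expected, a 2.0-fold higher number from compound 2 to compound 3 (0.30 log units; within the scatter), because compound 1 gives 631 nM with phenyl on that same nitrogen. Compound 3 is estimated at 500 nM, within 200 nM to 1500 nM.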

Compound 3, inhibition constant: 158 nM
Compound 3: middle estimate off by 3.2-fold (0.50 log units), on the high side; measured number outside the range, below it.
By their numbers in this assay, from the lowest: compounds 3 and 2 (each within the scatter of the next); then compound 1.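

In this assay phenyl in place of benzyl on the aromatic nitrogen gives a 1.6-fold lower number from compound 2 to compound 3 (0.20 log units; within the scatter) and so does not separate the two groups at this position, at least with the fluoro present. Among these compounds, with phenyl held on that nitrogen, fluoro in place of hydrogen on an aromatic carbon gives a 4.0-fold lower number from compound 1 to compound 3 (0.60 log units; beyond the scatter) and is the only single change here that lies beyond the scatter. Nothing offered here explains either step. Open, going by these compounds, is whether a longer chain such as phenethyl on that nitrogen would keep the number, and whether chloro or methoxy could stand in place of the fluoro.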